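The source may report more compounds than this note shows. Statements on the series, on what has been measured and on what is new or still open speak of the compounds shown alone.

Values in a functional assay, read by fluorescence and spectrophotometry, with a stated time of 1 h (on this read-out lower numbers stand for an effect already at smaller amounts and higher numbers for an effect only at larger amounts of compound), so far:
compound 1 `O=S(=O)(/C=C/c1ccc(O)c(O)c1)CCCCCCCO` gives 5900 nM
compound 2 `O=S(=O)(/C=C/c1ccc(O)c(O)c1)CCCCCCCCCO` gives 7500 nM
compound 3 `CCCCCCCS(=O)(=O)/C=C/c1ccc(O)c(O)c1` gives 7100 nM

Compound 3 at 7100 nM stands within the scatter of both other compounds, so the three sit at one level with no order among them. Next is compound 4 `CCCCCCCCCCS(=O)(=O)/C=C/c1ccc(O)c(O)c1` and its difference from compound 3 is propyl in place of hydrogen on a saturated chain carbon, seven bonds along the chain from a sulfonyl sulfur in counted terms. Cut one bond further out, the same difference reads methyl to butyl.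

Three measured steps fall at this same place: a 1.2-fold higher number from compound 1 to compound 3 (0.08 log units; within the scatter) with hydrogen replacing hydroxy, a 1.3-fold higher number from compound 1 to compound 2 (0.10 log units; within the scatter) with 2-hydroxyethyl replacing hydroxy, and a 1.1-fold lower number from compound 2 to compound 3 (0.02 log units; within the scatter) with hydrogen replacing 2-hydroxyethyl. All three lie within the scatter. Going by these compounds, none of them brings in propyl, so this exact change is untested. On these steps, no shift beyond the scatter is expected in this assay and the range is kept wide for the untested group. The estimated step is a 1.1-fold lower number from compound 3 to compound 4 (0.04 log units; within the scatter) and it is expected to stay within the scatter. For compound 4 the estimate is 6500 nM with an expected range of 3000 nM to 14000 nM as a working figure.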

Compound 4, half-maximal effective concentration: 6800 nM
The estimate for compound 4 lay 1.0-fold (0.02 log units) below the measured number; low and high end bracket the measured number.
By their numbers in this assay, from the lowest: compounds 1, 4, 3 and 2 (each within the scatter of the next).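

In this assay, propyl in place of hydrogen on a saturated chain carbon, seven bonds along the chain from a sulfonyl sulfur, gives a 1.0-fold lower number from compound 3 to compound 4 (0.02 log units; within the scatter) and so extends the group of tested changes at this place to a plain hydrocarbon addition, with no shift beyond the scatter. The comparisons with the two hydroxy-bearing chains read the same way: methyl in place of hydroxy on a saturated chain carbon, nine bonds along the chain from a sulfonyl sulfur, gives a 1.1-fold lower number from compound 2 to compound 4 (0.04 log units; within the scatter) and propyl in place of hydroxy at the seven-bond place gives a 1.2-fold higher number from compound 1 to compound 4 (0.06 log units; within the scatter) and neither swap leaves the scatter. No separate measurement is available to explain this lack of response.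

Going by these compounds, the four compounds sit at one level in this assay, so it remains open whether an amine or a carboxylic acid on the chain, or a longer chain, would move the number beyond the scatter. On these data alone, it also remains open whether a change in the shared core, such as methoxy in place of one of its hydroxy groups, would do so.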